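Replacing the hydroxy group: an expected loss of inhibition

The source may hold more compounds than are shown below. What is called first, only, known or untested is meant among the compounds shown, and "the series" means these compounds.

Measured compounds:
- compound 1 `C#CCn1c(-c2ccc(C(=O)N/N=C/c3cccn3C)cc2)nc2ccccc21`: >= 100000 nM
- compound 2 `C#CCn1c(-c2ccc(C(=O)N/N=C/c3ccc(Cl)cc3)cc2)nc2ccccc21`: >= 100000 nM
- compound 3 `C#CCn1c(-c2ccc(C(=O)N/N=C/c3ccc(O)cc3)cc2)nc2ccccc21`: 2820 nM

In an assay on cells for inhibition of Amine oxidase [flavin-containing] A (Homo sapiens), read by fluorescence and Amplex Red, with stated times of 30 min and 5 min (on this read-out lower numbers stand for stronger inhibition and higher numbers for weaker inhibition), compound 3 gives 2820 nM. For compound 1 the value is a limit of the assay, not a number. For compound 2 the value likewise is a limit. Among the measured compounds shown here, compound 3 is therefore the only compound with a measured number, standing clear of the limit at which the other two sit (the limit of >= 100000 nM in this assay, at which 2 of the 3 values shown sit).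

Compound 4 `C#CCn1c(-c2ccc(C(=O)N/N=C/c3ccccc3OC)cc2)nc2ccccc21` has not yet been measured. It differs from compound 3 by 2-methoxyphenyl in place of 4-hydroxyphenyl on a carbon with a double bond to nitrogen.

For the measured compounds named here, the step that bears on this change is the one from compound 2 to compound 3, where hydroxy replaced chloro on an aromatic carbon and the number fell: an at least 35-fold lower number from compound 2 to compound 3 (1.54 log units; beyond the scatter). The step of an at least 35-fold lower number from compound 1 to compound 3 (1.54 log units; beyond the scatter) points the same way. Compound 4 gives up the hydroxy group, so the expectation is a weaker result: the estimated step is an 11-fold higher number from compound 3 to compound 4 (1.03 log units; beyond the scatter), and compound 4 is expected at about 30000 nM, between 6000 nM and 150000 nM.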

Compound 4, half-maximal inhibitory concentration: >= 1000000 nM
Compound 4: no number, only a limit; the forecaster's own chance of this, stated with the estimate: 40%; middle value at least 33-fold (1.52 log units) away from the limit.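

In this assay, 2-methoxyphenyl in place of 4-hydroxyphenyl gives an at least 350-fold higher number from compound 3 to compound 4 (2.54 log units; beyond the scatter), so an oxygen on the aromatic ring is not enough on its own to keep a measurable inhibition. Of the compounds shown, only compound 3, with 4-hydroxyphenyl, gives a number, and the steps among compounds 1, 2 and 4 cannot be read. The value of compound 4 is a limit, not a number: the limit of >= 1000000 nM in this assay, at which 1 of the 4 values shown sits.

Compound 4 alters both the methyl on the oxygen and the ring position at once, and the compounds shown do not separate the two. From the compounds shown here alone, how 4-methoxyphenyl, 2-hydroxyphenyl or 4-aminophenyl would read at this position remains open.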